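Removing a Chain Methyl from a Furoxan-Linked Naphthoquinone Ester

The source may report more compounds than this note shows. Statements on the series, on what has been measured and on what is new or still open speak of the compounds shown alone.

The study concerns two measured compounds and one awaiting measurement, all built on the same core with a furoxan-bearing ester linker. Compound 1, with structure `CC1=C(CCC(=O)OCCCCOc2no[n+]([O-])c2S(=O)(=O)c2ccccc2)C(=O)c2c(O)cccc2C1=O`, is one of the measured pair. Compound 2 has the structure `CC1=C(C(C)CC(=O)OCC(C)COc2no[n+]([O-])c2S(=O)(=O)c2ccccc2)C(=O)c2c(O)cccc2C1=O` and carries a methyl on the chain that compound 1 lacks. In a functional assay on HepG2 cells (Homo sapiens) for inhibition, read by MTT assay, with a stated time of 72 h, tested at 10 uM (on this read-out lower numbers stand for less inhibition of growth and higher numbers for more inhibition of growth at the one concentration tested), compound 1 gives 95.4%, while compound 2 gives 91.5%; these two values lie within the scatter of each other, so no distinction can be drawn between them on this read-out. Compound 3, with structure `CC1=C(CCC(=O)OCC(C)COc2no[n+]([O-])c2S(=O)(=O)c2ccccc2)C(=O)c2c(O)cccc2C1=O`, differs from compound 2 by hydrogen in place of methyl on a saturated chain carbon bound to a double-bonded ring carbon and a saturated chain carbon. Within the data shown here, with no step between measured compounds available to guide the size of this change, and both measured values sitting close together, the step expected for this change is a number 1.5 percentage points higher from compound 2 to compound 3 (within the scatter), which is none beyond the scatter. Compound 3 is therefore estimated to reach 93% in this assay, with a range from 84% to 98%.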

Compound 3, percent growth inhibition at one concentration: 73.4%
For compound 3 the middle estimate is 19.6 percentage points above the measured one; the measured number lies below the stated range.
By their numbers in this assay, from the lowest: compound 3; then compounds 2 and 1 (each within the scatter of the next).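

In this assay, replacing the chain methyl with hydrogen gives a step of a number 18.1 percentage points lower from compound 2 to compound 3 (beyond the scatter). This shows that the position, on a saturated chain carbon bound to a double-bonded ring carbon and a saturated chain carbon, is sensitive to the loss of a single carbon atom. The earlier pair could not show this: compound 1 and compound 2 differ in more than one place, and their values lie within the scatter of each other. Nothing available explains the step, which stands here as an observation only.

On these data alone, whether an ethyl or a hydroxymethyl group at this position would hold the growth inhibition seen with methyl remains open. As far as these compounds go, it is also open whether the same exchange would give a step of similar size on a longer chain.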